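Oxamide replaces urea in a triarylethylene side chain

The source may hold more compounds than are shown below. What is called first, only, known or untested is meant among the compounds shown, and "the series" means these compounds.

Compound 1, `COc1ccc(/C(=C(/CCNC(=O)Oc2ccccc2)c2ccccc2)c2ccccc2)cc1`, in a functional assay on MCF7 cells (Homo sapiens) for cytotoxicity, read by MTT assay, with a stated time of 72 h; a higher number here means a weaker inhibitor, a lower number a stronger inhibitor: "not active" (no number reported)
Compound 2, `COc1ccc(/C(=C(/CCNC(=O)NCc2ccccc2)c2ccccc2)c2ccccc2)cc1`, in this assay: > 50000 nM
Compound 3, `CCN(CC)C(=O)NCC/C(=C(\c1ccccc1)c1ccc(OC)cc1)c1ccccc1`, in this assay: > 50000 nM

The three measured compounds share one core and differ only in the group carried on the carbonyl carbon of the side chain. Compound 1 is recorded as not active in this assay, without a number. For compound 2 the value in this assay is a limit of the assay. For compound 3 the value in this assay is likewise a limit of the assay, so compound 3 stands at the limit of > 50000 nM in this assay, at which 2 of the 3 values shown sit, and its place among the three cannot be ranked. Within the data shown here, the only single-point step, a step that the two limits leave unreadable from compound 2 to compound 3, is unreadable for the same reason.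

Compound 4, `COc1ccc(/C(=C(/CCNC(=O)C(=O)N2CCCC2)c2ccccc2)c2ccccc2)cc1`, differs from compound 3 by (pyrrolidin-1-yl)carbonyl in place of diethylamino on a carbonyl carbon. Among the measured compounds shown here, no measured step speaks to this change, and both neighbours of the change sit at the limit, so no direction can be drawn from the data. Compound 4 is therefore expected to remain near the limit, with an estimated step that the limit leaves unreadable from compound 3 to compound 4. The estimate for compound 4 in this assay is 80000 nM, within a range of 20000 nM to 300000 nM.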

Compound 4, half-maximal inhibitory concentration: > 50000 nM
Compound 4 gave a limit, no number; the forecaster's own chance of this, stated with the estimate: 80%; the middle value does not contradict the limit.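

Compound 4 gives a limit of the assay, not a number, and no step from compound 2 or compound 3 to compound 4 can be read: the limit of > 50000 nM in this assay, at which 3 of the 4 values shown sit.

The compounds shown leave open whether any group on the carbonyl carbon changes the read-out in this assay at all.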